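A few compounds are considered here, and "the series" means these few. Any claim that something is new, unique, unknown or untested is made for them only; others in the source may bear on it.

Compound 1 `C=CCCN1CCC(CCCn2c(COc3ccccc3)nc3c(OCCCN4CCCCC4)cccc32)CC1` gives 0.707 nM
Compound 2 `c1ccc(OCc2nc3c(OCCCN4CCCCC4)cccc3n2CCCC2CCN(CC3CCCCC3)CC2)cc1` gives 0.393 nM
Compound 3 `O=C(CCN1CCC(CCCn2c(COc3ccccc3)nc3c(OCCCN4CCCCC4)cccc32)CC1)c1ccccc1` gives 0.112 nM

These three compounds share one core and differ only in the group carried on the chain that hangs from the amine nitrogen in a ring. In an in vitro assay on AV12 cells for binding affinity to Neuropeptide Y receptor type 1 (Homo sapiens) (a higher number here means a weaker inhibitor, a lower number a stronger inhibitor), compound 1 has the highest number of the three. Compound 2 sits within the scatter of it, with a 1.8-fold lower number from compound 1 to compound 2 (0.26 log units; within the scatter). Compound 3 stands clearly apart: a 6.3-fold lower number from compound 1 to compound 3 (0.80 log units; beyond the scatter), and a 3.5-fold lower number from compound 2 to compound 3 (0.55 log units; beyond the scatter).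

Compound 4 `c1ccc(CCCN2CCC(CCCn3c(COc4ccccc4)nc4c(OCCCN5CCCCC5)cccc43)CC2)cc1` has not yet been measured in this assay. It comes from compound 1 by the change (benzyl in place of vinyl on a saturated chain carbon, two bonds along the chain from an amine nitrogen in a ring). Going by the values given here, the step that bears most directly on it is the one to compound 3, where benzoyl replaced vinyl at the same place and the number fell modestly, a 6.3-fold lower number from compound 1 to compound 3 (0.80 log units; beyond the scatter). Benzyl brings the same six-membered aromatic ring of carbon only as benzoyl but without its carbonyl, so a step in the same direction, probably somewhat smaller, is expected rather than a large one. The step to compound 2, where cyclohexyl replaced allyl on the ring nitrogen's chain carbon, stayed within the scatter, which keeps the expectation cautious.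

The estimate for compound 4 in this assay is 0.3 nM, with a likely range from 0.1 nM to 0.9 nM. That estimate would mean an expected step of a 2.4-fold lower number from compound 1 to compound 4 (0.37 log units; beyond the scatter).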

Compound 4, inhibition constant: 0.361 nM
Compound 4: the middle estimate sits 1.2-fold (0.08 log units) below what was measured; low and high end bracket the measured number.
By their numbers in this assay, from the lowest: compound 3; then compounds 4, 2 and 1 (each within the scatter of the next).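

In this assay, a six-membered aromatic ring of carbon only at this place does not by itself take the number beyond the scatter: benzyl in place of vinyl gives a 2.0-fold lower number from compound 1 to compound 4 (0.29 log units; within the scatter). Removing only the carbonyl does go beyond it, as benzyl in place of benzoyl gives a 3.2-fold higher number from compound 3 to compound 4 (0.51 log units; beyond the scatter), so in this pair the gap goes with the carbonyl and not with the ring alone. Phenethyl in place of cyclohexyl gives a 1.1-fold lower number from compound 2 to compound 4 (0.04 log units; within the scatter), so these two ring-bearing groups are not told apart here.

No supporting data are available to explain these differences. Going by these compounds, whether a hydroxyl group in place of the carbonyl, or a longer chain leading to it, would keep the number of compound 3 remains open.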